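Removing the Oxygen: Trifluoromethyl in Place of Trifluoromethoxy

The compounds below may be only part of what the source reports. "The series", "measured", "known", "first", "only" and "open" are said of these compounds alone.

Three compounds sharing one core were tested in a functional assay on A-375 cells (Homo sapiens) for antiproliferative activity, read by MTT assay, with a stated time of 24 h, tested at 3.7 ug/mL; a lower number here means a weaker effect, a higher number a stronger effect of the compound at the concentration tested. Compound 1 `CCc1ccc2nc(C(=O)Nc3c(F)cc(-c4cccc(F)c4)cc3F)c(C)c(O)c2c1` gives 17.9%. Compound 2 `CCOc1ccc2nc(C(=O)Nc3c(F)cc(-c4cccc(F)c4)cc3F)c(C)c(O)c2c1` gives 4.56%, and compound 3 `Cc1c(C(=O)Nc2c(F)cc(-c3cccc(F)c3)cc2F)nc2ccc(OC(F)(F)F)cc2c1O` gives 2.06%. Compound 3 has the lowest number of the three: its gap to compound 2 lies within the scatter, while a number 15.8 percentage points lower from compound 1 to compound 3 (beyond the scatter) and a number 13.3 percentage points lower from compound 1 to compound 2 (beyond the scatter) are both modest steps beyond it. The step of a number 2.5 percentage points lower from compound 2 to compound 3 (within the scatter) stays within the scatter.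

Compound 4 `Cc1c(C(=O)Nc2c(F)cc(-c3cccc(F)c3)cc2F)nc2ccc(C(F)(F)F)cc2c1O` differs from compound 3 in one place: trifluoromethyl in place of trifluoromethoxy on an aromatic carbon. Among the measured compounds shown here, no measured pair removes the oxygen from a trifluoromethoxy group directly. The nearest guide is compound 1 against compound 2, where ethyl without an oxygen stands above ethoxy; that step, a number 13.3 percentage points lower from compound 1 to compound 2 (beyond the scatter), is modest. On this basis a modest rise is expected for compound 4, with a number 6.9 percentage points higher from compound 3 to compound 4 (within the scatter) estimated to bring the number toward the middle of the three. The expected value for compound 4 is 9%, within a range from 0% to 22%.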

Compound 4, a percentage reported as inhibition, at one concentration (the size of the read-out at that concentration, not a potency): 34.3%
The estimate for compound 4 lay 25.3 percentage points below the measured number, and the stated range ends below it.
By their numbers in this assay, from the lowest: compounds 3 and 2 (each within the scatter of the next); then compound 1; then compound 4.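

In this assay this position separates two groups that differ by a single oxygen: the change to trifluoromethyl gives a number 32.2 percentage points higher from compound 3 to compound 4 (beyond the scatter) and is a large step. The same group also stands clear of the ethoxy group, with a number 29.7 percentage points higher from compound 2 to compound 4 (beyond the scatter) as a modest step, and of the ethyl group, with a number 16.4 percentage points higher from compound 1 to compound 4 (beyond the scatter) as another modest step, so ethyl no longer holds the top place. Across these four compounds, the two groups joined to the ring through carbon stand above the two joined through oxygen, and no compound goes against this.

On these data alone, whether an amine, a nitrile or a longer fluorinated chain at this position would follow the same pattern stays open, and a single concentration says nothing about potency. No measurement at hand accounts for the size of this change.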